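This account rests on a few compounds, and the source may have more. Where it says the series, first, only, none or still open, it means among the compounds named here.

Measured so far:
compound 1, `Fc1ccc2nc(-c3ccnnc3)n(C3CC3)c2c1`, an ADME assay on cells for inhibition of cytochrome P450 11B1, mitochondrial (Homo sapiens), read by HPLC, with a stated time of 60 min; a lower number here means a stronger inhibitor, a higher number a weaker inhibitor: > 10000 nM
compound 2, `CCc1ncncc1-c1nc2cc(F)c(F)cc2n1C1CC1`, this assay: 3330 nM

The value for compound 1 is a limit of this assay and not a number; compound 1 sits at the limit of > 10000 nM in this assay, at which 1 of the 2 values shown sits. For the measured compounds named here, compound 2 is the only compound in the pair with a number in this assay, its value being 3330 nM, so it stands as the sole fixed point for the series.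

The next compound, compound 3 with structure `CN(C)c1ncncc1-c1nc2cc(F)c(F)cc2n1C1CC1`, keeps the shared core of compound 2 and differs in one place: dimethylamino in place of ethyl on an aromatic carbon. Going by the values given here, no step between measured compounds with a number at both ends is available, so the size of this change can only be guessed from compound 2 alone. The expectation is a step from compound 2 to compound 3 of a 1.1-fold lower number from compound 2 to compound 3 (0.05 log units; within the scatter), which lies within the scatter of repeated measurements in this assay, with no direction claimed beyond it. Compound 3 is accordingly estimated at 3000 nM, with a range from 800 nM to 12000 nM.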

Compound 3, half-maximal inhibitory concentration: 4630 nM
Estimate against measurement, compound 3: 1.5-fold (0.19 log units) below; the measured number falls inside the stated range.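

Dimethylamino in place of ethyl on an aromatic carbon, next to the ring nitrogen and ortho to a large group, gives the series its first step with a number at both ends in this assay: a 1.4-fold higher number from compound 2 to compound 3 (0.14 log units; within the scatter) for this change. The exchange brings in a nitrogen and a hydrogen-bond acceptor at this position, yet the step stays within the scatter, so the two groups cannot be told apart here by their numbers in this assay. The values shown offer no measured basis for assigning a cause to this step.

On these data alone, how other groups at this position would read out remains open, among them methyl, a primary amine, methoxy or a longer chain such as propyl. For the compounds shown here, compound 1 gives > 10000 nM in this assay, which is a limit of the assay and not a number, and since it differs from the other compounds in more than one place, no step to it can be read.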